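Capping a Ring Amine With Carbamoyl in Chemokine Receptor Antagonists

This account rests on a few compounds, and the source may have more. Where it says the series, first, only, none or still open, it means among the compounds named here.

Compound 1 `CN1CCN(CCCN(C[C@H]2Cc3ccccc3CN2)[C@H]2CCCc3cccnc32)CC1`: in a functional assay on CCRF-CEM cells for antagonist activity at C-X-C chemokine receptor type 4 (Homo sapiens), read by calcium flux, with stated times of 25 min and 90 s (a higher number here means a weaker inhibitor, a lower number a stronger inhibitor), compound 1 gives 125 nM.
Compound 2 `c1ccc2c(c1)CN[C@@H](CN(CCCN1CCNCC1)[C@H]1CCCc3cccnc31)C2`: in this assay compound 2 gives 17 nM.

Compound 2 stands lowest of these two numbers, so it is the stronger inhibitor of the pair. Compound 3 `NC(=O)N1CCN(CCCN(C[C@H]2Cc3ccccc3CN2)[C@H]2CCCc3cccnc32)CC1` differs from it by carbamoyl in place of hydrogen on an amine nitrogen in a ring. Among the compounds with values here, the only step that bears on this place is a 7.4-fold lower number from compound 1 to compound 2 (0.87 log units; beyond the scatter), where hydrogen in place of methyl on that ring nitrogen gave the lower number. Putting a carbamoyl onto the same nitrogen is again a substitution there, so a step of comparable size in the opposite direction is expected, a 7.1-fold higher number from compound 2 to compound 3 (0.85 log units; beyond the scatter). Compound 3 is therefore estimated at 120 nM, between 40 nM and 400 nM.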

Compound 3, half-maximal inhibitory concentration: 959 nM
Estimate against measurement, compound 3: 8.0-fold (0.90 log units) below; the whole stated range lies below it.
By their numbers in this assay, from the lowest: compound 2; then compound 1; then compound 3.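

On this ring nitrogen, the two groups do not behave alike: in this assay, carbamoyl in place of hydrogen gives a 56-fold higher number from compound 2 to compound 3 (1.75 log units; beyond the scatter), and carbamoyl in place of methyl still gives a 7.7-fold higher number from compound 1 to compound 3 (0.88 log units; beyond the scatter). Among the three compounds, the number therefore rises from hydrogen to methyl to carbamoyl, so any group on this nitrogen raised it, but by an amount that depended on the group. Nothing measured here accounts for the size of these steps. From the compounds shown here alone, whether an acetyl group or a longer chain such as ethyl on this nitrogen would land nearer methyl or carbamoyl remains open.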